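The compounds below may be only part of what the source reports. "The series", "measured", "known", "first", "only" and "open" are said of these compounds alone.

Compound 2 `Cc1cc(NC(=O)Nc2ccc(F)cc2)c2ccccc2n1` is one of three compounds of a shared core examined in an ADME assay on Raji cells (Homo sapiens) for cytotoxicity, with a stated time of 72 h; on this read-out lower numbers stand for an effect already at smaller amounts and higher numbers for an effect only at larger amounts of compound. In this assay compound 2 gives > 25000 nM, a limit of the assay rather than a number. Compound 1 `Cc1cc(NC(=O)Nc2ncccc2C)c2ccccc2n1` gives > 25000 nM in this assay, again only a limit. Compound 3 `Cc1cc(NC(=O)Nc2ccc(F)cc2F)c2ccccc2n1` gives > 25000 nM in this assay, also a limit. Accordingly a step that the two limits leave unreadable from compound 1 to compound 2 and a step that the two limits leave unreadable from compound 2 to compound 3 remain unreadable, since all three values rest at the limit of > 25000 nM in this assay, at which 3 of the 3 values shown sit. Compound 4 `Cc1cc(NC(=O)Nc2ccc(OC(F)(F)F)cc2)c2ccccc2n1` differs from compound 2 by trifluoromethoxy in place of fluoro on an aromatic carbon. Neither measured step offers a readable size, so no step beyond the scatter can be expected in this assay from this change. Compound 4 is therefore expected to give 30000 nM in this assay, within 10000 nM to 100000 nM. The expected step comes to a step that the limit leaves unreadable from compound 2 to compound 4.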

Compound 4, half-maximal effective concentration: 10000 nM
Compound 4: the middle estimate sits 3.0-fold (0.48 log units) above what was measured, and the stated range covers the measured number.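

In this assay, trifluoromethoxy in place of fluoro on this aromatic carbon, para to a large group, gives the first readable step among these compounds, an at least 2.5-fold lower number from compound 2 to compound 4 (0.39 log units; beyond the scatter). This shows that the read-out can respond to a change at this position, which the earlier, unreadable steps could not show. Compound 4 alone carries a number, while the other compounds stay at a limit: the limit of > 25000 nM in this assay, at which 3 of the 4 values shown sit.

Going by these compounds, the full size of the step remains open, as the value for compound 2 is only a limit. Also open, on these data alone, is whether a methoxy group, an amine or a carboxylic acid at this position would likewise lower the number.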